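A few compounds are considered here, and "the series" means these few. Any claim that something is new, unique, unknown or untested is made for them only; others in the source may bear on it.

Measured compounds:
Compound 1, `O=C(/C=C/c1cn(-c2ccccc2)nc1-c1cccnc1)c1cc[nH]c1`: 3300 nM
Compound 2, `O=C(/C=C/c1cn(-c2ccccc2)nc1-c1cccnc1)c1ccccc1`: 2300 nM

In a functional assay on Huh-7 cells (Homo sapiens) for inhibition, read by sulforhodamine B assay, with a stated time of 72 h (on this read-out higher numbers stand for weaker inhibition and lower numbers for stronger inhibition), compound 2 gives the lowest of the two numbers available, and the nearest neighbour is compound 1. Going by the values given here, the only measured step, a 1.4-fold lower number from compound 1 to compound 2 (0.16 log units; within the scatter), lies within the scatter, so the two values do not separate the compounds.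

Compound 3, `O=C(/C=C/c1cn(-c2ccccc2)nc1-c1ccncc1)c1ccccc1`, differs from compound 2 in one place: pyridin-4-yl in place of pyridin-3-yl on an aromatic carbon. Among the compounds with values here, no measured step bears on this kind of change. Within the data shown here, the one step that is known concerns a different place, the group on the carbonyl carbon, and it was itself within the scatter. There is thus no basis for expecting a step beyond the scatter in either direction for this assay, and the expectation rests on compound 2 alone.

The estimate for compound 3 in this assay is therefore 2300 nM, with a range from 900 nM to 6000 nM. This estimate means an expected step of no change at the digits printed from compound 2 to compound 3 (within the scatter), which is expected to remain within the scatter of the assay.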

Compound 3, half-maximal inhibitory concentration: 1800 nM
Estimate against measurement, compound 3: 1.3-fold (0.11 log units) above, and the stated range covers the measured number.
By their numbers in this assay, from the lowest: compounds 3, 2 and 1 (each within the scatter of the next).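

In this assay the exchange of pyridin-3-yl for pyridin-4-yl, on the aromatic carbon next to the ring nitrogen, gives a 1.3-fold lower number from compound 2 to compound 3 (0.11 log units; within the scatter) and so does not separate the two compounds. Going by these compounds alone, this is the first reading at this position, since the earlier step concerned the group on the carbonyl carbon, and it shows that moving the ring nitrogen of this pyridine, with the heavy atoms and their counts unchanged, leaves the number within the scatter. No measurement is at hand that would say why this step is so small.

The compounds shown cover only two pyridine attachments at this position, so it remains open whether pyridin-2-yl, or a pyridine ring carrying an amine or a carboxylic acid, would move the number beyond the scatter. They also leave open whether pyridin-4-yl would read the same with 1H-pyrrol-3-yl on the carbonyl carbon, as each change has been read here only on its own.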